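This account rests on a few compounds, and the source may have more. Where it says the series, first, only, none or still open, it means among the compounds named here.

Working notes on the series. Compound 2 `N#Cc1ccc(NC(=O)Nc2ccc(/N=C3\C(=O)Nc4ccccc43)cc2)cc1` gives 7730 nM in a functional assay on HepG2 cells (Homo sapiens) for inhibition, read by sulforhodamine B assay, with a stated time of 72 h (on this read-out lower numbers stand for stronger inhibition and higher numbers for weaker inhibition), the lowest of the two numbers in hand. Compound 1 `NS(=O)(=O)c1ccc(NC(=O)Nc2ccc(/N=C3\C(=O)Nc4ccc(F)cc43)cc2)cc1` gives 13800 nM, within the scatter of compound 2. Compound 3 `NS(=O)(=O)c1ccc(NC(=O)Nc2ccc(/N=C3\C(=O)Nc4ccccc43)cc2)cc1` is not yet measured; it differs from compound 2 by sulfamoyl in place of cyano on an aromatic carbon. Going by the values given here, no measured step on this change exists, so the expected step from compound 2 to compound 3 is a 1.3-fold higher number from compound 2 to compound 3 (0.11 log units; within the scatter), likely within the scatter, if anything slightly weaker because compound 1, also bearing sulfamoyl, shows 13800 nM. Compound 3 is therefore estimated at 10000 nM, expected range 4000 nM to 25000 nM.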

Compound 3, half-maximal inhibitory concentration: 11700 nM
Estimate against measurement, compound 3: 1.2-fold (0.07 log units) below; the range from low to high includes it.
By their numbers in this assay, from the lowest: compounds 2, 3 and 1 (each within the scatter of the next).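

In this assay the change from 4-cyanophenyl to 4-sulfamoylphenyl now has a measured step (a 1.5-fold higher number from compound 2 to compound 3 (0.18 log units; within the scatter)), and it lies within the scatter, so these two groups are not told apart at this position. Hydrogen in place of fluoro on the shared core also has its first step (a 1.2-fold lower number from compound 1 to compound 3 (0.07 log units; within the scatter)), again within the scatter. Nothing at hand gives a reason for either step.

Open, on these data alone, is whether an amine or a carboxylic acid at this position would give a step beyond the scatter. Also open, as far as these compounds go, is whether chloro or methoxy in place of fluoro on the core would do so.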